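Notes on the step from compound 1 to compound 4

The compounds below may be only part of what the source reports. "The series", "measured", "known", "first", "only" and "open" are said of these compounds alone.

In a functional assay on UACC-62 cells (Homo sapiens) for cytotoxicity, read by sulforhodamine B assay (on this read-out lower numbers stand for stronger inhibition of growth and higher numbers for weaker inhibition of growth), compound 1 (`CC1=CC[C@@H]([C@@](C)(O)CCCC(C)(C)NC(=S)N/N=C\c2ccc(C)cc2)CC1`) gives 39000 nM, the higher of the two actual numbers in the series. Compound 3 (`CC1=CC[C@@H]([C@@](C)(O)CCCC(C)(C)NC(=S)N/N=C\c2ccccc2[N+](=O)[O-])CC1`) gives 16600 nM. Compound 2 (`CC1=CC[C@@H]([C@@](C)(O)CCCC(C)(C)NC(=S)N/N=C\c2ccc(N(C)C)cc2)CC1`) gives > 100000 nM, which is a limit of the assay and not a number.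

Compound 4 (`CC1=CC[C@@H]([C@@](C)(O)CCCC(C)(C)NC(=S)N/N=C(/C)c2ccccc2)CC1`) is still unmeasured. Its change from compound 1 is a group of 9 heavy atoms (8 carbon, 1 nitrogen; one six-membered aromatic ring of carbon only) in place of a group of 9 heavy atoms (8 carbon, 1 nitrogen; one six-membered aromatic ring of carbon only), on an amide-type nitrogen; the two have the same atoms, joined differently.

Three measured steps alter the aromatic part of the series: an at least 2.5-fold higher number from compound 1 to compound 2 (0.40 log units; beyond the scatter), a 2.3-fold lower number from compound 1 to compound 3 (0.37 log units; beyond the scatter) and an at least 6.0-fold lower number from compound 2 to compound 3 (0.77 log units; beyond the scatter). These steps show that this assay responds to changes there, but none of them makes this same change, so they give no direction for it. Their sizes argue for a wide range, with no firm shift from compound 1.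

The expected result is a 1.1-fold lower number from compound 1 to compound 4 (0.05 log units; within the scatter).

For compound 4 the estimated value is 35000 nM, with an expected range of 14000 nM to 90000 nM.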

Compound 4, concentration for total growth inhibition: 93300 nM
Compound 4: middle estimate off by 2.7-fold (0.43 log units), on the low side, and the stated range ends below it.
By their numbers in this assay, from the lowest: compound 3; then compound 1; then compound 4. At a limit, above all of these: compound 2.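

In this assay, rejoining the same atoms in the group on the amide-type nitrogen gives a 2.4-fold higher number from compound 1 to compound 4 (0.38 log units; beyond the scatter), so the series responds to how this group is joined even when its atom count stays the same. The earlier steps shown here all exchanged atoms, and this one runs in the same direction as an at least 2.5-fold higher number from compound 1 to compound 2 (0.40 log units; beyond the scatter) but against a 2.3-fold lower number from compound 1 to compound 3 (0.37 log units; beyond the scatter). Compound 4 still reads as a number, but further weakening in this part of the series may reach the top of the read-out: the limit of > 100000 nM in this assay, at which 1 of the 4 values shown sits.

As far as these compounds go, it remains open whether an ethyl group or a longer chain, joined where the group of compound 4 carries its extra carbon, would shift the number further. From the compounds shown here alone, it is equally open whether a 2-nitrophenyl group joined in the manner of compound 4 would keep the lower number of compound 3.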